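The source may hold more compounds than are shown below. What is called first, only, known or untested is meant among the compounds shown, and "the series" means these compounds.

Working notes on the series.

Three compounds have numbers in an assay on cell membranes for binding affinity to Adrenergic receptor alpha-1 (Rattus norvegicus), read by radioligand binding; a higher number here means a weaker inhibitor, a lower number a stronger inhibitor: compound 1 `COc1ccccc1N1CCN(CCCCn2ncc(N3CCN(C(=O)c4ccco4)CC3)c(Cl)c2=O)CC1`, compound 2 `O=C(c1ccco1)N1CCN(c2ccc(=O)n(CCCCCN3CCN(c4ccccc4Cl)CC3)n2)CC1` and compound 3 `COc1ccccc1N1CCN(CCCCCCCn2nc(N3CCN(C(=O)c4ccco4)CC3)ccc2=O)CC1`. In this assay compound 1 gives 33.5 nM, compound 2 gives 13.3 nM, and compound 3 gives 54.7 nM. Compound 3 thus carries the highest of the three numbers; the gap to compound 1 lies within the usual scatter, while the gap to compound 2 lies beyond it. For the measured compounds named here, no single-point step connects any two of these measured compounds, so the pairs can only be read as what their two values show.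

Compound 4 `O=C(c1ccco1)N1CCN(c2ccc(=O)n(CCCCCCCN3CCN(c4ccccc4Cl)CC3)n2)CC1` has not been measured in this assay. It differs from compound 3 by chloro in place of methoxy on an aromatic carbon, on an aromatic carbon of a six-membered aromatic ring of carbon only, ortho to a large group; taken one bond further out, this is 2-methoxyphenyl to 2-chlorophenyl. Going by the values given here, the one measured compound bearing 2-chlorophenyl, compound 2, sits at the low end of the series with 13.3 nM, though its chain also differs from that of compound 3, so the comparison is not clean. The step from compound 3 to compound 4 is expected to be modest and toward a lower number, a 2.2-fold lower number from compound 3 to compound 4 (0.34 log units; beyond the scatter). For compound 4 the expected value in this assay is 25 nM, with a range from 9 nM to 70 nM.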

Compound 4, inhibition constant: 5.6 nM
For compound 4 the middle estimate is 4.5-fold (0.65 log units) above the measured one, outside the stated range (below it).
By their numbers in this assay, from the lowest: compound 4; then compound 2; then compounds 1 and 3 (each within the scatter of the next).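

For the compounds shown here, the step of a 9.8-fold lower number from compound 3 to compound 4 (0.99 log units; beyond the scatter) in this assay gives the first clean reading of this position: 2-methoxyphenyl to 2-chlorophenyl is the only difference, and the step lies beyond the scatter. Going by these compounds alone, until now the one compound with 2-chlorophenyl, compound 2, also differed from the 2-methoxyphenyl compounds elsewhere, so its low number could not be assigned to this group; the change itself can now be seen to lower the number with the rest of compound 3 held fixed. What lies behind the size of the step cannot be said from the data in hand, since no measurement bears on it.

Whether the same step holds on other chains stays open, since compound 2 has no 2-methoxyphenyl partner with its chain among the compounds shown, and the chloro pair here rests on a single chain. Also open, as far as these compounds go, is how far the number moves with fluoro, methyl or plain hydrogen on the same aromatic carbon, as only methoxy and chloro have been seen at this place.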